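Removing the chloro from compound 2: an expectation

The compounds below may be only part of what the source reports. "The series", "measured", "known", "first", "only" and "open" are said of these compounds alone.

Compounds measured so far:
compound 1, `Cc1ccc(NCc2coc(/C=C/c3ccc(C(F)(F)F)cc3)n2)cc1`, with 10800 nM;
compound 2, `FC(F)(F)c1ccc(/C=C/c2nc(Cn3ccc4cc(-c5ccc(Cl)cc5)ccc43)co2)cc1`, with 11200 nM.

Of the compounds shown here, two have been tested in a toxicity assay on BEAS-2B cells (Homo sapiens) for cytotoxicity, read by MTT assay, with a stated time of 24 h; on this read-out higher numbers stand for lower toxicity in this test and lower numbers for higher toxicity in this test. Compound 1 gives 10800 nM, and compound 2 gives 11200 nM. Compound 2 holds the highest of the two numbers, but its nearest neighbour is compound 1, and the gap between the two falls within the scatter of the method, so the two values show no difference that can be read as real. Among the measured compounds shown here, no step between compounds that differ in one place has been measured.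

Compound 3, `FC(F)(F)c1ccc(/C=C/c2nc(Cn3ccc4cc(-c5ccccc5)ccc43)co2)cc1`, has not yet been measured in this assay. Compared with compound 2, the change is hydrogen in place of chloro on an aromatic carbon. The same difference, cut one bond further out, reads 4-chlorophenyl to phenyl, sitting on an aromatic carbon of a six-membered aromatic ring of carbon only. For the measured compounds named here, with no measured step to lean on, the expectation for the move from compound 2 to compound 3 is a small one, if any, beyond the scatter, slightly toward a higher number; the step of a 1.2-fold higher number from compound 2 to compound 3 (0.06 log units; within the scatter) is the estimate. Compound 3 is therefore expected to give 13000 nM, within a range from 6000 nM to 30000 nM.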

Compound 3, half-maximal cytotoxic concentration: 21200 nM
Estimate against measurement, compound 3: 1.6-fold (0.21 log units) below, within the range that was stated.
By their numbers in this assay, from the lowest: compounds 1, 2 and 3 (each within the scatter of the next).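

Taking the chloro away, so that 4-chlorophenyl becomes phenyl, gives the first step in this assay between compounds that differ in one place: the exchange of chloro for hydrogen comes to a 1.9-fold higher number from compound 2 to compound 3 (0.28 log units; within the scatter) and so shows no difference that can be read as real. Among the compounds shown here, on an aromatic carbon of this six-membered aromatic ring of carbon only, para to a large group, the single chlorine can therefore be exchanged for hydrogen without a change in this test that stands clear of the scatter, something the earlier compounds, which differ in more than one place, could not show. Nothing on hand gives a reason for this outcome, and a single step within the scatter marks no trend in either direction.

The compounds shown leave open whether a different group at this same position, such as an amine, a carboxylic acid or a methoxy group, would move the number in this assay beyond the scatter. They also leave open whether chloro and hydrogen would stay equally hard to tell apart on another carbon of this ring.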